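The compounds below may be only part of what the source reports. "The series", "measured", "known", "first", "only" and "open" are said of these compounds alone.

Compound 2 `CC(C)C[C@H](N)c1cc(C(F)(F)F)ccc1N1CCN(C(=O)CSc2ccc(Cl)cc2Cl)CC1` gives the higher of two numbers in an assay on HEK293 cells for displacement of a labelled ligand from Melanocortin receptor 4 (Homo sapiens) (on this read-out lower numbers stand for stronger inhibition and higher numbers for weaker inhibition), with 1500 nM; compound 1 `CC(C)C[C@H](N)c1cc(C(F)(F)F)ccc1N1CCN(C(=O)CCC(=O)c2ccc(Cl)cc2)CC1` gives 820 nM, and the step of a 1.8-fold higher number from compound 1 to compound 2 (0.26 log units; within the scatter) lies within the scatter. Compound 3 `Cc1ccc(CC(C)C(=O)N2CCN(c3ccc(C(F)(F)F)cc3[C@@H](N)CC(C)C)CC2)cc1C` has 1-(3,4-dimethylbenzyl)ethyl in place of ((2,4-dichlorophenyl)sulfanyl)methyl on a carbonyl carbon. Among the measured compounds shown here, the only measured step exchanges a different group at the same carbonyl carbon, so it offers little guidance, and both measured numbers sit close together. The step of a 1.3-fold lower number from compound 2 to compound 3 (0.10 log units; within the scatter) is therefore expected to stay within the scatter. For compound 3 the expected value in this assay is 1200 nM, with a range of 350 nM to 4500 nM.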

Compound 3, inhibition constant: 240 nM
For compound 3 the middle estimate is 5.0-fold (0.70 log units) above the measured one; measured number below the stated range.
By their numbers in this assay, from the lowest: compound 3; then compounds 1 and 2 (each within the scatter of the next).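

Placing 1-(3,4-dimethylbenzyl)ethyl on this carbonyl carbon brings a 6.3-fold lower number from compound 2 to compound 3 (0.80 log units; beyond the scatter) and a 3.4-fold lower number from compound 1 to compound 3 (0.53 log units; beyond the scatter) in this assay and shows that this position can respond to a change of group. Both steps lie beyond the scatter, unlike the earlier exchange at the same carbon, and compound 3 has the lowest number of the three. Nothing available explains this difference.

It remains open which part of the 1-(3,4-dimethylbenzyl)ethyl group accounts for these steps. How an amine or a carboxylic acid at this position would read is also unknown.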